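Methoxy to fluoro on the aryl ring: a repeated step

This account rests on a few compounds, and the source may have more. Where it says the series, first, only, none or still open, it means among the compounds named here.

Measured compounds in a functional assay on SW620/5-FU cells (Homo sapiens) for cytotoxicity, read by MTT assay, with a stated time of 48 h, in the presence of a further agent that is not named here; on this read-out higher numbers stand for an effect only at larger amounts of compound and lower numbers for an effect already at smaller amounts:
- compound 1 `COc1ccc(-c2cc(NNC(=O)Nc3cc(Cl)nc(OC)c3)nc3c2cnn3C)cc1`, 48800 nM
- compound 2 `COc1cc(NC(=O)NNc2cc(-c3ccc(F)cc3)c3cnn(C)c3n2)cc(Cl)n1`, 24100 nM
- compound 3 `CCCCOc1cc(NC(=O)NNc2cc(-c3ccc(OC)cc3)c3cnn(C)c3n2)cc(Cl)n1`, 39200 nM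

Compound 4 `CCCCOc1cc(NC(=O)NNc2cc(-c3ccc(F)cc3)c3cnn(C)c3n2)cc(Cl)n1` has not yet been measured. The two cores differ in the way counted as propyl in place of hydrogen on a saturated chain carbon bound to an oxygen on an aromatic ring, a change that gave a 1.2-fold lower number from compound 1 to compound 3 (0.10 log units; within the scatter), so the core of compound 3 and the core of compound 1 behave alike within the scatter. The change from compound 3 to compound 4 is fluoro in place of methoxy on an aromatic carbon. The same change, (fluoro in place of methoxy on an aromatic carbon), occurs once before among the measured compounds and gave a 2.0-fold lower number from compound 1 to compound 2 (0.31 log units; beyond the scatter). Going by the values given here, with only one earlier instance, and both places described in the same words, a step of about the same size is expected; compound 4 is therefore estimated at a 2.0-fold lower number from compound 3 to compound 4 (0.29 log units; within the scatter) relative to compound 3, within a range of 9000 nM to 45000 nM. Compound 4 is expected to give 20000 nM in this assay.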

Compound 4, half-maximal effective concentration: 29300 nM
For compound 4 the middle estimate is 1.5-fold (0.17 log units) below the measured one, within the range that was stated.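

In this assay, fluoro in place of methoxy gives a 1.3-fold lower number from compound 3 to compound 4 (0.13 log units; within the scatter), and this step reads alike on the two cores: the same change on two cores in this assay, a 2.0-fold lower number (0.31 log units; beyond the scatter) from compound 1 to compound 2 and a 1.3-fold lower number (0.13 log units; within the scatter) from compound 3 to compound 4, 1.5-fold (0.18 log units) apart, within the scatter of two such steps. Propyl in place of hydrogen on the chain bound to the oxygen gives a 1.2-fold higher number from compound 2 to compound 4 (0.08 log units; within the scatter), and this step also reads alike on the two cores: the same change on two cores in this assay, a 1.2-fold lower number (0.10 log units; within the scatter) from compound 1 to compound 3 and a 1.2-fold higher number (0.08 log units; within the scatter) from compound 2 to compound 4, 1.5-fold (0.18 log units) apart, within the scatter of two such steps. These two pairs of steps show agreement between two cores within the scatter, but they do not show that either change would carry over to other cores in the series.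

The compounds shown leave open how a nitrile or an amine in place of the fluoro of the 4-fluorophenyl group would read. As far as these compounds go, a longer chain on the oxygen, or one ending in a carboxylic acid, also remains open.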